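Aryl exchange on the shared core: compound 2 to compound 3

This account rests on a few compounds, and the source may have more. Where it says the series, first, only, none or still open, it means among the compounds named here.

Among the compounds with values here, in a functional assay on A549 cells (Homo sapiens) for cytotoxicity, read by MTT assay, with a stated time of 48 h (on this read-out lower numbers stand for stronger inhibition and higher numbers for weaker inhibition), compound 1 `C=C(c1ccc(OC)cc1)c1cc(OC)c(OC)c(OC)c1-c1ccc(OC)cc1` gives 14000 nM and compound 2 `C=C(c1ccc(OC)cc1)c1cc(OC)c(OC)c(OC)c1-c1ccc(F)c(F)c1` gives 6500 nM, the lower of the two numbers so far. Next in view is compound 3 `C=C(c1ccc(OC)cc1)c1cc(OC)c(OC)c(OC)c1-c1ccc(C(C)(C)C)cc1`, which differs from compound 2 as follows: 4-(tert-butyl)phenyl in place of 3,4-difluorophenyl on an aromatic carbon. The exchange is 4-(tert-butyl)phenyl in place of 3,4-difluorophenyl, ortho to a 1-(4-methoxyphenyl)ethenyl group. Within the data shown here, one measured step bears on this place: a 2.2-fold lower number from compound 1 to compound 2 (0.33 log units; beyond the scatter), a modest one, with 3,4-difluorophenyl replacing 4-methoxyphenyl. Among the measured compounds shown here, no measured compound carries 4-(tert-butyl)phenyl, so the evidence is thin. With 3,4-difluorophenyl gone, a return towards compound 1 at 14000 nM is expected. The expected step is a 2.2-fold higher number from compound 2 to compound 3 (0.33 log units; beyond the scatter), modest in size and towards a higher number. In this assay the estimate for compound 3 is 14000 nM, with an expected range from 6000 nM to 32000 nM.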

Compound 3, half-maximal inhibitory concentration: 27000 nM
Estimate against measurement, compound 3: 1.9-fold (0.29 log units) below; the measured number falls inside the stated range.
By their numbers in this assay, from the lowest: compound 2; then compounds 1 and 3 (each within the scatter of the next).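

In this assay, a second exchange at this position, ortho to a 1-(4-methoxyphenyl)ethenyl group, gives a 4.2-fold higher number from compound 2 to compound 3 (0.62 log units; beyond the scatter) and leaves 3,4-difluorophenyl as the only one of the three aryl groups with a number set apart from the others. Replacing the methoxy of 4-methoxyphenyl with tert-butyl gives a 1.9-fold higher number from compound 1 to compound 3 (0.29 log units; within the scatter), so the assay does not separate 4-methoxyphenyl from 4-(tert-butyl)phenyl at this position. Nothing available explains the difference between 3,4-difluorophenyl and the other two groups.

Open, from the compounds shown here alone, is whether a single fluorine is enough to give the lower number of compound 2, and how an aryl group carrying a hydroxyl, an amine or a carboxylic acid reads at this position. Going by these compounds, the 1-(4-methoxyphenyl)ethenyl group and the methoxy groups stay the same throughout, so their part remains untested.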